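This account rests on a few compounds, and the source may have more. Where it says the series, first, only, none or still open, it means among the compounds named here.

Compound 1 `C[C@@H]1CN(c2cc(C(F)(F)F)nn2-c2ccc(S(C)(=O)=O)cn2)[C@H](C)CO1` is the reference point of this set. In a physicochemical assay for solubility (on this read-out lower numbers stand for lower solubility and higher numbers for higher solubility), compound 1 gives 100 ug/mL. Compound 2 `C[C@@H]1CN(c2c(C#N)c(C(F)(F)F)nn2-c2ccc(S(C)(=O)=O)cn2)[C@H](C)CO1` differs from it only in one place: cyano in place of hydrogen on an aromatic carbon. The value of compound 2 in this assay is a limit of the assay, > 200 ug/mL. The step of an at least 2.0-fold higher number from compound 1 to compound 2 (0.30 log units; that floor lies within the scatter) is therefore a floor rather than a measured size, since compound 2 sits at the limit of > 200 ug/mL in this assay, at which 1 of the 3 values shown sits.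

Compound 3 `CC(C)COc1cc(C(F)(F)F)nn1-c1ccc(S(C)(=O)=O)cn1` carries a different core; the difference between the two cores is a group of 5 heavy atoms (4 carbon, 1 oxygen; no ring) in place of a group of 8 heavy atoms (6 carbon, 1 nitrogen, 1 oxygen; one six-membered non-aromatic ring with 2 hetero atoms), on an aromatic carbon. In this assay compound 3 gives 50 ug/mL, and the step of a 2.0-fold lower number from compound 1 to compound 3 (0.30 log units; within the scatter) is small.

Compound 4 `CC(C)COc1c(C#N)c(C(F)(F)F)nn1-c1ccc(S(C)(=O)=O)cn1` has not been measured. It stands to compound 3 as compound 2 stands to compound 1: cyano in place of hydrogen on an aromatic carbon. The surroundings of the new group are not identical, since in compound 2 the cyano sits next to the ring atom that bears a group of 8 heavy atoms, whereas in compound 4 it sits next to the ring atom that bears an isobutoxy group (5 heavy atoms), so the change is of the same kind, not the same.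

For compound 4 in this assay a step of about a 2.0-fold higher number from compound 3 to compound 4 (0.30 log units; within the scatter) is expected, resting on the step of an at least 2.0-fold higher number from compound 1 to compound 2 (0.30 log units; that floor lies within the scatter), which is only a floor. The starting point for that expected step is compound 3 at 50 ug/mL. Compound 4 is estimated at 100 ug/mL, with a likely span from 50 ug/mL to 250 ug/mL.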

Compound 4, solubility: < 25 ug/mL
Compound 4 gave a limit, no number; the forecaster's own chance of this, stated with the estimate: 20%; middle value at least 4.0-fold (0.60 log units) away from the limit.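

Compound 4 stands at a limit of this assay, not at a number: the limit of < 25 ug/mL in this assay, at which 1 of the 4 values shown sits. Cyano in place of hydrogen gives an at least 2.0-fold higher number from compound 1 to compound 2 (0.30 log units; that floor lies within the scatter) on the core of compound 1 and an at least 2.0-fold lower number from compound 3 to compound 4 (0.30 log units; that floor lies within the scatter) on the core of compound 3; as printed, the two steps point in opposite ways, but each is only a floor within the scatter, so this one pair of cores shows that the earlier step cannot be assumed to carry over, and it fixes neither true size nor a firm direction. With cyano present, the exchange of the group of 8 heavy atoms for the isobutoxy group gives an at least 8.0-fold lower number from compound 2 to compound 4 (0.90 log units; beyond the scatter), whereas the same exchange without cyano gives a 2.0-fold lower number from compound 1 to compound 3 (0.30 log units; within the scatter), which suggests that the outcome of the cyano change depends on the group it accompanies in these four compounds, though the data do not say why.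

The compounds shown leave open whether a primary amine or a longer alkoxy chain in place of the isobutoxy group would follow compound 2 or compound 4. They also leave open whether a carboxylic acid or a primary amide in place of cyano would give the same split between the two cores.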